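Fluoro in Place of Hydrogen on Compound 1

The source may report more compounds than this note shows. Statements on the series, on what has been measured and on what is new or still open speak of the compounds shown alone.

Compound 1 `Cc1ccc(NC(=O)N[C@H](C)c2ccccc2)cc1`: 98%
Compound 2 `C[C@@H](NC(=O)Nc1ccc(C(C)(C)C)cc1)c1ccccc1`: 88%
Compound 3 `CCCCCc1ccc(NC(=O)N[C@H](C)c2ccccc2)cc1`: 101%

In an ADME assay on the whole organism with Oryza sativa as the target, tested at 1 uM (a higher number here means a weaker effect of the compound at the concentration tested, a lower number a stronger effect), compound 1 stands second highest of the three numbers. Its nearest neighbour is compound 3, with a number 3 percentage points higher from compound 1 to compound 3 (within the scatter); its furthest is compound 2, with a number 10 percentage points lower from compound 1 to compound 2 (within the scatter). For the measured compounds named here, the one step beyond the scatter is a number 13 percentage points higher from compound 2 to compound 3 (beyond the scatter), a modest one.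

Compound 4 `Cc1ccc(NC(=O)N[C@H](C)c2ccccc2)c(F)c1` differs from compound 1 by fluoro in place of hydrogen on an aromatic carbon. Going by the values given here, no measured step exchanges hydrogen for fluoro; all three vary only the alkyl group on the aromatic carbon, and each stays small. The expectation for compound 4 is therefore a step of a number 2 percentage points lower from compound 1 to compound 4 (within the scatter), that is, none beyond the scatter. The estimate for compound 4 is 96%, with a range from 84% to 104%.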

Compound 4, a percentage reported as activity, at one concentration (the size of the read-out at that concentration, not a potency): 99%
Estimate against measurement, compound 4: 3 percentage points below; low and high end bracket the measured number.
By their numbers in this assay, from the lowest: compounds 2, 1, 4 and 3 (each within the scatter of the next, the first and the last beyond it).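

this assay had so far been probed only through the alkyl group on the aromatic carbon; this result is the first reading at the ring carbon ortho to a large group and meta to a methyl group. Fluoro in place of hydrogen there gives a number 1 percentage points higher from compound 1 to compound 4 (within the scatter), so at this position the two cannot be told apart in this read-out. No evidence here bears on this result.

As far as these compounds go, whether a larger group at this carbon, such as chloro, methoxy or an amine, would give a step beyond the scatter remains open. So does whether fluoro would read the same alongside the tert-butyl group of compound 2.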